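The compounds below may be only part of what the source reports. "The series", "measured", "known", "first", "only" and "open" are said of these compounds alone.

Measured so far:
Compound 1, `Nc1ccc(S(=O)(=O)Nc2ccnc3cc(C(F)(F)F)ccc23)cc1`: 31000 nM
Compound 2, `O=C(Nc1ccccc1)Nc1ccc(S(=O)(=O)Nc2ccnc3cc(C(F)(F)F)ccc23)cc1`: 52900 nM
Compound 3, `NS(=O)(=O)c1ccc(N/C(S)=N\c2ccnc3cc(C(F)(F)F)ccc23)cc1`: 52900 nM

All three were tested in a functional assay on MDA-MB-231 cells (Homo sapiens) for antiproliferative activity, read by sulforhodamine B assay, with a stated time of 48 h; a lower number here means a stronger inhibitor, a higher number a weaker inhibitor. Compound 1 gives 31000 nM. Compound 2 gives 52900 nM, and compound 3 gives 52900 nM, so compound 3 stands level with compound 2 at the digits shown, while its gap to compound 1 is within the scatter; none of the three can be separated from the others.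

Compound 4, `Cc1noc(NS(=O)(=O)c2ccc(N/C(S)=N\c3ccnc4cc(C(F)(F)F)ccc34)cc2)c1C`, has not yet been measured. It differs from compound 3 in one place: 3,4-dimethyl-1,2-oxazol-5-yl in place of hydrogen on a sulfonamide nitrogen. Within the data shown here, only one measured step is of a similar kind, the attachment of a group to a nitrogen: a 1.7-fold higher number from compound 1 to compound 2 (0.23 log units; within the scatter). That step sits at a different nitrogen and brought no change beyond the scatter. On that single comparison, the step expected from this change is a 1.2-fold lower number from compound 3 to compound 4 (0.07 log units; within the scatter), nothing beyond the scatter in either direction. For compound 4 the estimate is 45000 nM, with a range from 15000 nM to 120000 nM.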

Compound 4, half-maximal inhibitory concentration: 27900 nM
For compound 4 the middle estimate is 1.6-fold (0.21 log units) above the measured one; measured number inside the range.
By their numbers in this assay, from the lowest: compounds 4, 1, 2 and 3 (each within the scatter of the next).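

Among these compounds, compound 3 carries only hydrogen on its sulfonamide nitrogen, so the earlier compounds gave no direct view of what a group at this position would do. In this assay the step is a 1.9-fold lower number from compound 3 to compound 4 (0.28 log units; within the scatter) and so shows that adding 3,4-dimethyl-1,2-oxazol-5-yl, a five-membered aromatic ring with two methyl groups, does not shift the number beyond the scatter of repeated measurements. No measurement is available that could explain this result.

The compounds shown leave open whether a smaller group such as methyl or acetyl, or a plain phenyl ring, would behave the same way on this nitrogen. They also leave open whether the two methyl groups on the new ring matter, which the unsubstituted 1,2-oxazol-5-yl group could test.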